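Replacing the Methoxy Group of Compound 1

The source may report more compounds than this note shows. Statements on the series, on what has been measured and on what is new or still open speak of the compounds shown alone.

Measured in a functional assay on NALM-6 cells (Homo sapiens) for cytotoxicity, with a stated time of 72 h; on this read-out lower numbers stand for an effect already at smaller amounts and higher numbers for an effect only at larger amounts of compound:
- Compound 1 `C=C[C@@](C)(/C=C/c1ccc(OC)cc1)CCC=C(C)C`: > 43400 nM
- Compound 2 `C=C[C@@](C)(/C=C/c1ccc(O)c(/C=C/C(=O)NCc2ccc(C(F)(F)F)cc2)c1)CCC=C(C)C`: > 43400 nM
- Compound 3 `CC(C)=CCC[C@@](C)(/C=C/c1ccccc1)/C=C/c1ccc(O)cc1`: > 43400 nM

Compound 1 has no numerical value, only > 43400 nM, which is a limit of the assay. The other two compounds are no different, and the whole set amounts to the limit of > 43400 nM in this assay, at which 3 of the 3 values shown sit.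

Compound 4 `C=C[C@@](C)(/C=C/c1ccc(Nc2ccc(OC)cc2)cc1)CCC=C(C)C` keeps the core of compound 1 but carries (4-methoxyphenyl)amino in place of methoxy on an aromatic carbon, para to a large group: (4-methoxyphenyl)amino in place of methoxy on an aromatic carbon. Among the compounds with values here, no measured step in this assay shows what a change of this kind does. A modest move toward lower numbers is expected, though another limit remains quite possible. That caution rests on compound 1, which sits at the limit of > 43400 nM. The estimated change is an at least 1.7-fold lower number from compound 1 to compound 4 (0.23 log units; that floor lies within the scatter). For compound 4 the expected value is 25000 nM, with an estimated range of 6000 nM to 60000 nM.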

Compound 4, half-maximal effective concentration: > 43400 nM
Compound 4 gave a limit, no number (the forecaster's own chance of this, stated with the estimate: 55%); at least 1.7-fold (0.23 log units) between middle value and limit.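

In this assay compound 4 gives > 43400 nM, a limit and not a number. With compound 1 also at a limit, no step can be read between compound 1 and compound 4: the limit of > 43400 nM in this assay, at which 4 of the 4 values shown sit.

The compounds shown leave open whether any change to the core of compound 1 brings a measurable value.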